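A few compounds are considered here, and "the series" means these few. Any claim that something is new, unique, unknown or untested is made for them only; others in the source may bear on it.

Compound 3, `Cc1noc(-c2nc(C)c3c(c2N)C(=O)N(Cc2ccc(Cl)cc2)C3=O)n1`, gives in a physicochemical assay for solubility, using the shake flask method, in simulated intestinal fluid, measured as kinetic solubility, with a stated time of 2 h, at 25 degrees C, at pH 6.5 (a higher number here means a more soluble compound, a lower number a less soluble compound), a value of < 5000 nM, which is a limit of the assay rather than a number. The other two values shown come from a different pair of compounds. Compound 1, `Cc1nc(C#N)c(N)c2c1C(=O)N(Cc1ccccc1)C2=O`, gives in this assay a value of < 5000 nM, again a limit of the assay. Compound 2, `Cc1nc(C(=O)NC#N)c(N)c2c1C(=O)N(Cc1ccccc1)C2=O`, gives in this assay a value of 185000 nM. Among the compounds with values here, the one measured step, an at least 37-fold higher number from compound 1 to compound 2 (1.56 log units; beyond the scatter), concerns cyanocarbamoyl in place of cyano on an aromatic carbon and does not touch the part of the structure that changes here. Two of the three values shown sit at the limit, (the limit of < 5000 nM in this assay, at which 2 of the 3 values shown sit).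

Compound 4, `Cc1noc(-c2nc(C)c3c(c2N)C(=O)N(Cc2ccc(N(C)C)cc2)C3=O)n1`, differs from compound 3 by dimethylamino in place of chloro on an aromatic carbon. Within the data shown here, no measured step bears on this change, so the expected step from compound 3 to compound 4 in this assay rests on the limit alone and is estimated as an at least 1.2-fold higher number from compound 3 to compound 4 (0.07 log units; that floor lies within the scatter). Compound 4 is therefore estimated at 6000 nM in this assay, within a range from 2000 nM to 25000 nM.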

Compound 4, solubility: 7400 nM
Compound 4: middle estimate off by 1.2-fold (0.09 log units), on the low side; measured number inside the range.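

In this assay compound 3 gives < 5000 nM, which is a limit of the assay and not a number. With dimethylamino in place of chloro on an aromatic carbon para to a large group, compound 4 gives a real number at this position, 7400 nM. The step, an at least 1.4-fold higher number from compound 3 to compound 4 (0.17 log units; that floor lies within the scatter), is only a floor, so the true size of this change cannot be read, and the floor alone does not separate the two compounds: the limit of < 5000 nM in this assay, at which 2 of the 4 values shown sit.

The compounds shown leave open how far compound 3 lies under its limit, and so how large this step really is. They also leave open how a primary amine, a morpholine ring or a carboxylic acid would read at this position, and whether the same change would give a similar step on the core of compound 1.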